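Removing a Chlorine from the Benzoyl Group: a Cytotoxicity Estimate

A few compounds are considered here, and "the series" means these few. Any claim that something is new, unique, unknown or untested is made for them only; others in the source may bear on it.

Measured so far:
compound 1 `O=C(NC(=S)NNc1ncnc2ccccc12)c1ccccc1`: 2330 nM
compound 2 `O=C(NC(=S)NNc1ncnc2ccccc12)c1ccc(Cl)cc1`: 3940 nM
compound 3 `COc1cc2ncnc(NNC(=S)NC(=O)c3cccc(Cl)c3)c2cc1OC`: 4830 nM

In a functional assay on KB cells (Homo sapiens) for cytotoxicity, read by MTT assay, with a stated time of 72 h (a higher number here means a weaker inhibitor, a lower number a stronger inhibitor), compound 1 gives 2330 nM, compound 2 gives 3940 nM and compound 3 gives 4830 nM. The change hydrogen in place of chloro on an aromatic carbon produced a 1.7-fold lower number from compound 2 to compound 1 (0.23 log units; within the scatter). The difference between the cores of compound 2 and compound 3 is not broken down here. Compound 4 `COc1cc2ncnc(NNC(=S)NC(=O)c3ccccc3)c2cc1OC` is not yet measured; it arises from compound 3 by hydrogen in place of chloro on an aromatic carbon. This is the same kind of change as that from compound 2 to compound 1, though there the hydrogen enters para to a large group and here meta to a large group. Resting on compound 2 and compound 1 and their step of a 1.7-fold lower number from compound 2 to compound 1 (0.23 log units; within the scatter), a similar small step is expected, a 1.6-fold lower number from compound 3 to compound 4 (0.21 log units; within the scatter). Compound 4 is estimated at 3000 nM, between 1200 nM and 7500 nM.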

Compound 4, half-maximal inhibitory concentration: 3770 nM
Estimate against measurement, compound 4: 1.3-fold (0.10 log units) below; the measured number falls inside the stated range.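

In this assay, hydrogen in place of chloro gave a 1.3-fold lower number from compound 3 to compound 4 (0.11 log units; within the scatter). Set beside the earlier step, the change reads alike on the two cores: the same change on two cores in this assay, a 1.7-fold lower number (0.23 log units; within the scatter) from compound 2 to compound 1 and a 1.3-fold lower number (0.11 log units; within the scatter) from compound 3 to compound 4, 1.3-fold (0.12 log units) apart, within the scatter of two such steps. This shows that the change carried across these two pairs without a visible difference, but both steps lie within the scatter, so it does not show that removing the chlorine shifts the number at all, and the hydrogen enters at a different place in each pair, so core and place are not separated.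

The compounds shown leave open whether a methoxy group, a nitro group or an amine on the benzoyl ring would carry between these cores in the same way. Two pairs also cannot establish a rule for the wider series.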